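The source may report more compounds than this note shows. Statements on the series, on what has been measured and on what is new or still open speak of the compounds shown alone.

Of the compounds shown here, three sharing one core have been tested in a functional assay on HCT-116 cells (Homo sapiens) for cytotoxicity, read by MTT assay, with a stated time of 72 h; a higher number here means a weaker inhibitor, a lower number a stronger inhibitor. Compound 1 `CN1[C@@H]2c3[nH]c4ccccc4c3C[C@H]1[C@H](C#N)N1[C@@H](CNC(=O)c3cccc(C(F)(F)F)c3)c3[nH]c4ccccc4c3C[C@@H]21` gives 630 nM; compound 2 `CN1[C@@H]2c3[nH]c4ccccc4c3C[C@H]1[C@H](C#N)N1[C@@H](CNC(=O)c3ccc4ccccc4c3)c3[nH]c4ccccc4c3C[C@@H]21` gives 420 nM; compound 3 `CN1[C@@H]2c3[nH]c4ccccc4c3C[C@H]1[C@H](C#N)N1[C@@H](CNC(=O)c3ccc4ccccc4n3)c3[nH]c4ccccc4c3C[C@@H]21` gives 240 nM. For the measured compounds named here, compound 3 has the lowest of the three numbers, though its gap to compound 2 is within the scatter, and only the step of a 2.6-fold lower number from compound 1 to compound 3 (0.42 log units; beyond the scatter) lies beyond it; the steps of a 1.5-fold lower number from compound 1 to compound 2 (0.18 log units; within the scatter) and a 1.8-fold lower number from compound 2 to compound 3 (0.24 log units; within the scatter) are both within the scatter.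

Compound 4 `CN1[C@@H]2c3[nH]c4ccccc4c3C[C@H]1[C@H](C#N)N1[C@@H](CNC(=O)c3cc4ccccc4[nH]3)c3[nH]c4ccccc4c3C[C@@H]21` differs from compound 3 in a single place: 1H-indol-2-yl in place of quinolin-2-yl on a carbonyl carbon. All three measured steps are exchanges of the aryl group on the same carbonyl carbon, and each was small, so a further exchange of this kind is expected to move this assay little, with no direction beyond the scatter to be expected. Compound 4 is therefore estimated at 300 nM, within the range 120 nM to 750 nM, which means an expected step of a 1.3-fold higher number from compound 3 to compound 4 (0.10 log units; within the scatter).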

Compound 4, half-maximal inhibitory concentration: 880 nM
Compound 4: the middle estimate sits 2.9-fold (0.47 log units) below what was measured, and the stated range ends below it.
By their numbers in this assay, from the lowest: compounds 3, 2, 1 and 4 (each within the scatter of the next, the first and the last beyond it).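

In this assay, exchanges of the aryl group on this carbonyl carbon are no longer uniformly small: 1H-indol-2-yl lies beyond the scatter against both fused six-membered partners (a 3.7-fold higher number from compound 3 to compound 4 (0.56 log units; beyond the scatter); a 2.1-fold higher number from compound 2 to compound 4 (0.32 log units; beyond the scatter)), while it stays within the scatter against 3-(trifluoromethyl)phenyl (a 1.4-fold higher number from compound 1 to compound 4 (0.15 log units; within the scatter)). The position therefore distinguishes quinolin-2-yl from 1H-indol-2-yl, an exchange in which a five-membered aromatic ring and a hydrogen-bond donor enter and a hydrogen-bond acceptor leaves. No supporting measurement is available to explain this difference.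

From the compounds shown here alone, it remains open which of those structural differences goes with the higher number. Also open, going by these compounds, is how groups such as 1-methyl-1H-indol-2-yl or benzofuran-2-yl would read in this assay.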